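Removing a fluorine from a bis-furan amidine

A few compounds are considered here, and "the series" means these few. Any claim that something is new, unique, unknown or untested is made for them only; others in the source may bear on it.

Measured compounds:
- compound 1, `N=C(N)c1ccc(-c2ccc(-c3ccc(F)cc3)o2)o1`: 90%
- compound 2, `N=C(N)c1ccc(-c2ccc(-c3cc(Cl)cc(Cl)c3)s2)s1`: 17%
- compound 3, `COc1cc(-c2ccc(-c3ccc(C(=N)N)s3)s2)cc(OC)c1OC`: 79.7%

All three were tested in an ADME assay on cells (Erythrocyte, Homo sapiens) for activation, read by hemolysis, with a stated time of 30 min, tested at 10 mM; a lower number here means a weaker effect, a higher number a stronger effect of the compound at the concentration tested. Compound 1 gives 90%, the highest of the three numbers. Its nearest neighbour is compound 3, which gives 79.7%, a lower number and a gap beyond the usual scatter. Furthest away is compound 2, which gives 17%, far lower and clearly beyond the scatter. Since both gaps lie beyond the scatter, compound 1 is the strongest of the three in this assay.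

Compound 4, `N=C(N)c1ccc(-c2ccc(-c3ccccc3)o2)o1`, has not yet been tested in this assay. It differs from compound 1 in one place only: hydrogen in place of fluoro on an aromatic carbon. Within the data shown here, the change is small, a single fluorine atom giving way to hydrogen, and no measured pair shows what such a change does here. The expected step in this assay from compound 1 to compound 4 is therefore small, at most a slight drop, and likely within the scatter: a number 6 percentage points lower from compound 1 to compound 4 (within the scatter). Compound 4 is estimated to give 84%, with a range from 62% to 97%.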

Compound 4, a percentage reported as activity, at one concentration (the size of the read-out at that concentration, not a potency): 66.7%
Compound 4: middle estimate off by 17.3 percentage points, on the high side; low and high end bracket the measured number.
By their numbers in this assay, from the lowest: compound 2; then compound 4; then compound 3; then compound 1.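

In this assay, among these compounds, the swap of fluoro for hydrogen on an aromatic carbon, para to a large group, gives a number 23.3 percentage points lower from compound 1 to compound 4 (beyond the scatter) and is the first one-place comparison available in this set. It shows that this position is not silent: the loss of one heavy atom, with the rest of the core of compound 1 unchanged, is enough to shift the read-out by more than the usual scatter. No measurement at hand bears on why the number falls with this change.

The compounds shown do not tell whether a methyl group, a nitrile or an amine on this same carbon would land nearer to compound 1 or to compound 4. They also leave open whether the same swap would shift the number similarly on the core of compound 2.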